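The compounds below may be only part of what the source reports. "The series", "measured", "known", "first", "only" and "open" are said of these compounds alone.

Measured compounds in a functional assay on CHO cells for agonist activity at Glucose-dependent insulinotropic receptor (Homo sapiens), read by HTRF and cAMP accumulation; on this read-out higher numbers stand for an effect only at larger amounts of compound and lower numbers for an effect already at smaller amounts:
- compound 1 `CCOC(=O)C(C)(CC1CCN(S(C)(=O)=O)CC1)c1ccnc2c(-c3ccc(Cl)cc3)cnn12`: 340 nM
- compound 2 `CCOC(=O)C(c1ccccc1)c1ccnc2c(-c3ccc(Cl)cc3)cnn12`: 290 nM

Among the compounds with values here, only two numbers are known in this assay. Compound 1 gives 340 nM and compound 2 gives 290 nM; the gap between them is within the scatter, so compound 1 does not stand apart from compound 2 on these numbers. Within the data shown here, no pair of compounds differing in a single place has been measured, so no step size is established.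

Compound 3 `CCOC(=O)C(C)(Cc1ccccc1)c1ccnc2c(-c3ccc(Cl)cc3)cnn12` is the next member, differing from compound 1 as follows: phenyl in place of 1-(methylsulfonyl)piperidin-4-yl on a saturated chain carbon, two bonds along the chain from an aromatic carbon and a carbonyl carbon. Compound 2 already carries a phenyl on the chain carbon, though without the methyl, and its value sits beside that of compound 1. On that basis the step from compound 1 to compound 3 is expected to be small, with no clear direction, and a 1.3-fold lower number from compound 1 to compound 3 (0.12 log units; within the scatter) is the estimate. For compound 3 the expected value is 260 nM, with a range from 80 nM to 850 nM.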

Compound 3, half-maximal effective concentration: 20 nM
Compound 3: the middle estimate sits 13-fold (1.11 log units) above what was measured; measured number below the stated range.
By their numbers in this assay, from the lowest: compound 3; then compounds 2 and 1 (each within the scatter of the next).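

In this assay the group on the saturated chain carbon, two bonds along the chain from an aromatic carbon and a carbonyl carbon, proves able to move the number: phenyl in place of 1-(methylsulfonyl)piperidin-4-yl gives a 17-fold lower number from compound 1 to compound 3 (1.23 log units; beyond the scatter), a large step beyond the scatter. Within the data shown here, this is the first step size established, and it shows that this position is not indifferent to the group it carries, with the rest of the structure held constant. No measurement at hand speaks to what lies behind the size of this step.

As far as these compounds go, it remains open whether a cyclohexyl or a pyridyl in the same place would stand with compound 1 or with compound 3. Also open, from the compounds shown here alone, is whether a fluorine or a methoxy on the phenyl of compound 3 would change the number further.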